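Phenyl in place of methyl: expected inhibition of compound 3

This account rests on a few compounds, and the source may have more. Where it says the series, first, only, none or still open, it means among the compounds named here.

Compound 1 `Cc1ccc(S(=O)(=O)NNC(N)=S)cc1` and compound 2 `CC(=O)N(c1nc(C)cs1)N(C(C)=O)S(=O)(=O)c1ccc(C)cc1` have both been measured in a functional assay on HepG2 cells (Homo sapiens) for inhibition, read by XTT assay, with a stated time of 72 h; on this read-out higher numbers stand for weaker inhibition and lower numbers for stronger inhibition. In this assay compound 1 gives 8980 nM, and compound 2 gives 7360 nM, the two numbers lying within the usual scatter of each other, so neither can be placed ahead of the other. Compound 3 `CC(=O)N(c1nc(-c2ccccc2)cs1)N(C(C)=O)S(=O)(=O)c1ccc(C)cc1` is not yet measured; it differs from compound 2 by phenyl in place of methyl on an aromatic carbon. Among the compounds with values here, no measured pair shows this change, so its size is open. A small step toward stronger inhibition, not clearly beyond the scatter, is expected a 1.8-fold lower number from compound 2 to compound 3 (0.26 log units; within the scatter). For compound 3 the estimate in this assay is 4000 nM, with a range of 1500 nM to 12000 nM.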

Compound 3, half-maximal inhibitory concentration: > 58200 nM
Compound 3 gave a limit, no number; the forecaster's own chance of this, stated with the estimate: 5%; middle value at least 14-fold (1.16 log units) from the limit.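

In this assay, phenyl in place of methyl on the aromatic carbon next to the ring nitrogen gives an at least 7.9-fold higher number from compound 2 to compound 3 (0.89 log units; beyond the scatter), the first step read at this position, and it runs toward weaker inhibition. This position is therefore not indifferent to the group it carries. Compound 3 gives a limit and not a number, so the step has no upper end: the limit of > 58200 nM in this assay, at which 1 of the 3 values shown sits.

With methyl and phenyl as the only groups shown here, the effect of an ethyl chain, an amine or a carboxylic acid at this position remains open.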